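The source may report more compounds than this note shows. Statements on the series, on what has been measured and on what is new or still open speak of the compounds shown alone.

Measured so far in an assay on isolated protein for inhibition of Fatty-acid amide hydrolase 1 (Homo sapiens), read by fluorescence, with a stated time of 30 min; a lower number here means a stronger inhibitor, a higher number a weaker inhibitor:

Compound 1 `NC(=O)c1cc(-c2ccc(OC(=O)NC3CCCCC3)cc2)n(-c2ccccc2)n1`: compound 1 gives 71 nM.
Compound 2 `NC(=O)c1cc(-c2ccc(OC(=O)NC3CCCCC3)cc2)n(-c2ccc(Cl)cc2)n1`: compound 2 gives 172 nM.
Compound 3 `CCOC(=O)c1cc(-c2ccc(OC(=O)NC3CCCCC3)cc2)nn1-c1ccccc1`: compound 3 gives 592 nM.

Compound 2 differs from compound 1 by chloro in place of hydrogen on an aromatic carbon, and the measured step is a 2.4-fold higher number from compound 1 to compound 2 (0.38 log units; beyond the scatter). Compound 3 carries the highest number of the three; the difference between its core and the core of compound 1 is not broken down here, so the two values are simply set side by side.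

Compound 4 `CCOC(=O)c1cc(-c2ccc(OC(=O)NC3CCCCC3)cc2)nn1-c1ccc(Cl)cc1` has not yet been measured. It differs from compound 3 by chloro in place of hydrogen on an aromatic carbon, the same change that separates compound 1 from compound 2, made on the same kind of position.

In this assay compound 4 is expected to give 1400 nM, with a likely range from 600 nM to 3500 nM. For the measured compounds named here, the expected step from compound 3 is a 2.4-fold higher number from compound 3 to compound 4 (0.37 log units; beyond the scatter), resting on the single earlier instance a 2.4-fold higher number from compound 1 to compound 2 (0.38 log units; beyond the scatter); with only one precedent the expectation is held loosely, and a result within the scatter of compound 3 would not be surprising.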

Compound 4, half-maximal inhibitory concentration: 586 nM
Compound 4: middle estimate off by 2.4-fold (0.38 log units), on the high side, and the stated range ends above it.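

In this assay, phenyl to 4-chlorophenyl on the core of compound 3 gives a 1.0-fold lower number from compound 3 to compound 4 (0.00 log units; within the scatter), whereas the same change on the core of compound 1 gave a step beyond the scatter. Even so, the two steps cannot be told apart: the same change on two cores in this assay, a 2.4-fold higher number (0.38 log units; beyond the scatter) from compound 1 to compound 2 and a 1.0-fold lower number (0.00 log units; within the scatter) from compound 3 to compound 4, 2.4-fold (0.39 log units) apart, within the scatter of two such steps. With one step on each core, the data neither show that the change carries over from one core to the other nor show that the two cores respond differently, and the size of the step on either core remains loosely defined.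

The compounds shown leave open whether a fluoro, methyl or methoxy group in place of the chloro would give steps that clearly agree or clearly differ between the two cores. They also leave open how a carboxylic acid in place of the ethyl ester of compound 3 would read in this assay, with or without the chloro.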